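Indole attachment point shifted on a fused-ring kinase-type scaffold

A few compounds are considered here, and "the series" means these few. Any claim that something is new, unique, unknown or untested is made for them only; others in the source may bear on it.

Compound 3 `Cn1c(=O)c(S(=O)(=O)c2ccc(F)cc2)cc2cnc(Nc3ccc4cc[nH]c4c3)nc21` stands at the top of the numbers recorded in a functional assay on DU-145 cells (Homo sapiens) for inhibition, read by trypan blue exclusion, with a stated time of 72 h (on this read-out higher numbers stand for weaker inhibition and lower numbers for stronger inhibition), where compound 3 gives 10000 nM. Compound 2 `Cn1c(=O)c(S(=O)(=O)c2ccc(F)cc2)cc2cnc(Nc3cnc4[nH]ccc4c3)nc21` gives 500 nM, and compound 1 `Cn1c(=O)c(S(=O)(=O)c2ccc(F)cc2[N+](=O)[O-])cc2cnc(Nc3ccc4[nH]ccc4c3)nc21` gives 1500 nM. Among the compounds with values here, the one measured step, a 20-fold higher number from compound 2 to compound 3 (1.30 log units; beyond the scatter), shows how strongly the group on the nitrogen on an aromatic ring governs the read-out. Compound 4 `Cn1c(=O)c(S(=O)(=O)c2ccc(F)cc2)cc2cnc(Nc3ccc4[nH]ccc4c3)nc21` keeps the same atoms as compound 3 but joins them differently: 1H-indol-5-yl in place of 1H-indol-6-yl on a nitrogen on an aromatic ring. Within the data shown here, no measured step covers this exact change. Compound 1, however, also carries 1H-indol-5-yl on the nitrogen on an aromatic ring, and its value sits well below that of compound 3, while compound 2 lies lower still. Because compound 3 gives 10000 nM and compound 1 gives 1500 nM, the expectation is a clear fall in number, with the estimated step of a 10-fold lower number from compound 3 to compound 4 (1.00 log units; beyond the scatter). Compound 4 is therefore expected to give about 1000 nM, within a range from 300 nM to 4000 nM.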

Compound 4, half-maximal inhibitory concentration: 300 nM
Compound 4: the middle estimate sits 3.3-fold (0.52 log units) above what was measured; the measured number falls inside the stated range.
By their numbers in this assay, from the lowest: compounds 4 and 2 (each within the scatter of the next); then compound 1; then compound 3.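

In this assay, the change from (1H-indol-6-yl)amino to (1H-indol-5-yl)amino, with the same atoms joined differently, gives a 33-fold lower number from compound 3 to compound 4 (1.52 log units; beyond the scatter) and so shows that the attachment point of the indole alone can govern the read-out. The step of a 1.7-fold lower number from compound 2 to compound 4 (0.22 log units; within the scatter) shows that the 1H-indol-5-yl group and the group of compound 2, with a nitrogen in its six-membered ring, cannot be told apart here, although the 1H-indol-6-yl group stands well clear of that group. With the 1H-indol-5-yl group held constant, hydrogen in place of nitro gives a 5.0-fold lower number from compound 1 to compound 4 (0.70 log units; beyond the scatter) as a separate and smaller effect on the read-out.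

Going by these compounds, how an amine or a carboxylic acid on the 1H-indol-5-yl group would read remains open, as does whether the attachment point counts as much in compounds carrying the nitro group. Nothing at hand explains why the attachment point matters.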